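Cytotoxicity notes on a triazolethione series: compound 4

The source may hold more compounds than are shown below. What is called first, only, known or untested is meant among the compounds shown, and "the series" means these compounds.

Measured so far:
compound 1 `Cc1ccc(COc2n[nH]c(=S)n2/N=C/c2c[nH]nc2-c2ccc(F)cc2)cc1`: 45 ug/mL
compound 2 `Fc1ccc(-c2n[nH]cc2/C=N/n2c(OCc3ccccc3)n[nH]c2=S)cc1`: 71 ug/mL
compound 3 `Cc1ccc(COc2nn(CN(c3ccccc3)c3ccccc3)c(=S)n2/N=C/c2c[nH]nc2-c2ccc(F)cc2)cc1`: 90 ug/mL

All three numbers come from a functional assay on HepG2 cells (Homo sapiens) for cytotoxicity, read by MTT assay, with a stated time of 24 h; on this read-out lower numbers stand for stronger inhibition and higher numbers for weaker inhibition. Compound 1 gives the lowest of the three numbers, but its nearest neighbour is compound 2 and its furthest is compound 3, and both gaps are within the scatter, so no order among the three can be claimed. Within the data shown here, the only single-point step in the set, a 1.6-fold higher number from compound 1 to compound 2 (0.20 log units; within the scatter), is within the scatter.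

The next compound is compound 4 `CCc1n[nH]cc1/C=N/n1c(OCc2ccc(C)cc2)n[nH]c1=S`. Relative to compound 1 the change is ethyl in place of 4-fluorophenyl on an aromatic carbon. Among the measured compounds shown here, it sits on an aromatic carbon of a five-membered aromatic ring with 2 nitrogen, next to the ring nitrogen, whereas the one measured step concerns a different ring and a different group, so it does not speak directly to this change. For the measured compounds named here, no measured pair exchanges the 4-fluorophenyl for a chain.

With that in mind, compound 4 is expected near the value of compound 1, at an estimated 55 ug/mL with a range of 25 ug/mL to 130 ug/mL. Going by the values given here, the step this estimate means, a 1.2-fold higher number from compound 1 to compound 4 (0.09 log units; within the scatter), is expected to stay within the scatter, with the range kept wide because no measured step covers this position.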

Compound 4, half-maximal inhibitory concentration: > 100 ug/mL
Compound 4: a limit, no number (the forecaster's own chance of this, stated with the estimate: 10%); middle value at least 1.8-fold (0.25 log units) away from the limit.
By their numbers in this assay, from the lowest: compounds 1, 2 and 3 (each within the scatter of the next). At a limit, above all of these: compound 4.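

In this assay compound 4 gives > 100 ug/mL, which is a limit of the assay and not a number. Among these compounds, the exchange of 4-fluorophenyl for ethyl on this aromatic carbon comes with an at least 2.2-fold higher number from compound 1 to compound 4 (0.34 log units; beyond the scatter), the first single-place step to lie beyond the scatter, whereas the one earlier step, a 1.6-fold higher number from compound 1 to compound 2 (0.20 log units; within the scatter), stayed within it. This position therefore responds to the change in a way the earlier compounds could not show, though the size of the step is only a lower bound and rests on a limit: the limit of > 100 ug/mL in this assay, at which 1 of the 4 values shown sits.

With only 4-fluorophenyl and ethyl shown at this place, it remains open whether the difference follows the loss of the aromatic ring, the loss of the fluorine or simply the smaller group, and an unsubstituted phenyl, a longer chain such as butyl or an amine on the same carbon would separate these readings. As far as these compounds go, it also remains open how far the true value of compound 4 lies from its limit, so the full size of the step cannot yet be stated.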